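The compounds below may be only part of what the source reports. "The series", "measured", "known", "first", "only" and "open" are said of these compounds alone.

Among the compounds with values here, compound 2 `Cc1ccc(Nc2nc(-c3cc(C(=O)Nc4ccccc4)no3)cs2)cc1` is the only compound of this pair for which an ADME assay on microsomes from liver (Homo sapiens) for metabolic stability, read by LC-MS, tested at 1 uM (a higher number here means faster removal of the compound, a lower number slower removal), reports a number: in this assay compound 2 shows 17.8 mL/min/kg. Its neighbour, compound 1 `CCOC(=O)c1cc(-c2csc(Nc3ccc(C)cc3)n2)on1`, gives in this assay only > 400 mL/min/kg, which is a limit of the assay rather than a number. Within the data shown here, the single measured step, an at least 22-fold lower number from compound 1 to compound 2 (1.35 log units; beyond the scatter), is consequently known only as a bound, because the limit of > 400 mL/min/kg in this assay, at which 1 of the 2 values shown sits, caps what the assay can report for compound 1. Compound 3 `Cc1ccc(Nc2nc(-c3cc(C(=O)Nc4ccccn4)no3)cs2)cc1` differs from compound 2 by pyridin-2-yl in place of phenyl on an amide-type nitrogen. Among the measured compounds shown here, no measured step touches this amide-type nitrogen: the one step on record, from compound 1 to compound 2, concerns the carbonyl carbon and exchanges an ethoxy for an anilino, so it offers no direct guide to a change one ring further out. With nothing in the data pointing beyond the scatter in either direction, the expected change for compound 3 in this assay is a 1.1-fold higher number from compound 2 to compound 3 (0.05 log units; within the scatter), inside the usual scatter. Compound 3 is accordingly estimated at 20 mL/min/kg, with a likely range from 8 mL/min/kg to 50 mL/min/kg.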

Compound 3, clearance: 38.8 mL/min/kg
Compound 3: middle estimate off by 1.9-fold (0.29 log units), on the low side, within the range that was stated.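

Within the data shown here, this is the first measured change on the amide-type nitrogen, and it shows that the position is not indifferent in this assay: exchanging a single ring carbon of the phenyl for nitrogen, to give pyridin-2-yl, produces a 2.2-fold higher number from compound 2 to compound 3 (0.34 log units; beyond the scatter) and so moves the number in the direction of faster removal. The large drop seen with anilino on the carbonyl carbon is largely kept with the new group, since (pyridin-2-yl)amino in place of ethoxy still gives an at least 10-fold lower number from compound 1 to compound 3 (1.01 log units; beyond the scatter) and remains a large step. That step is known only as a bound, because compound 1 stands at a limit rather than at a number: the limit of > 400 mL/min/kg in this assay, at which 1 of the 3 values shown sits.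

The compounds shown leave open whether the rise depends on where the nitrogen sits in the ring, which pyridin-3-yl and pyridin-4-yl groups would test, or on the presence of a ring nitrogen at all, which a pyrimidin-2-yl group would probe further. They also leave open how a saturated group such as cyclohexyl on the amide-type nitrogen, or a methyl group on that nitrogen itself, would fare in this assay against phenyl.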